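Cyclopropyl in place of trifluoromethyl on a series at the limit

The compounds below may be only part of what the source reports. "The series", "measured", "known", "first", "only" and "open" are said of these compounds alone.

Three compounds sharing one core have been examined in an assay on membranes from Jurkat cells for displacement of a labelled ligand from Sigma intracellular receptor 2 (Homo sapiens), read by scintillation counting, with a stated time of 1 h; on this read-out lower numbers stand for stronger inhibition and higher numbers for weaker inhibition. Compound 1 `Cc1ccc(-c2nc(CN3CCCC3)nn2C)cc1` carries a methyl on an aromatic carbon; in this assay compound 1 gives > 1000 nM, which is a limit of the assay and not a number. Compound 2 `Cn1nc(CN2CCCC2)nc1-c1ccc(Cl)cc1` carries chloro in place of that methyl, and in this assay compound 2 gives > 1000 nM, again a limit. Compound 3 `Cn1nc(CN2CCCC2)nc1-c1ccc(C(F)(F)F)cc1` carries trifluoromethyl in the same place, and in this assay compound 3 gives > 1000 nM, also a limit. The steps a step that the two limits leave unreadable from compound 1 to compound 2, a step that the two limits leave unreadable from compound 1 to compound 3 and a step that the two limits leave unreadable from compound 2 to compound 3 cannot be sized, since (the limit of > 1000 nM in this assay, at which 3 of the 3 values shown sit). On the numbers shown, compound 3 therefore stands at the limit, as do compounds 1 and 2. Compound 4 `Cn1nc(CN2CCCC2)nc1-c1ccc(C2CC2)cc1` differs from compound 3 by cyclopropyl in place of trifluoromethyl on an aromatic carbon. Among the compounds with values here, none of the measured steps bears on this change in a readable way; each of them is hidden behind the same limit. The expected outcome for compound 4 is accordingly a step that the limit leaves unreadable from compound 3 to compound 4, with the number itself uncertain. Compound 4 is estimated at 2000 nM, within a range from 500 nM to 8000 nM, and with a strong chance that this assay again reports only a limit.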

Compound 4, inhibition constant: 1000 nM
Compound 4: the middle estimate sits 2.0-fold (0.30 log units) above what was measured; low and high end bracket the measured number.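

In this assay compound 4 gives 1000 nM as an actual number, the first in this series that is not a limit, so cyclopropyl on this aromatic carbon gives the position its first measured value among the four groups shown. Compound 3 gives > 1000 nM as a limit of the assay. Within the data shown here, the result is a number no higher from compound 1 to compound 4 (the limit leaves the size open) and a number no higher from compound 2 to compound 4 (the limit leaves the size open), which shows only that the value of compound 4 is no higher than theirs and gives no size for the change, because the other three values all rest on one limit: the limit of > 1000 nM in this assay, at which 3 of the 4 values shown sit.

The compounds shown leave open how far compounds 1, 2 and 3 lie from compound 4, and therefore whether replacing trifluoromethyl with cyclopropyl changes the binding by a little or a lot. With a number no higher from compound 3 to compound 4 (the limit leaves the size open) as all that is shown for this change, they also leave open what an isopropyl, a tert-butyl, a methoxy or an amine on the same aromatic carbon would give in this assay and whether any of these would yield a number clearly lower than that of compound 4.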